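The compounds below may be only part of what the source reports. "The series", "measured", "known", "first", "only" and "open" are said of these compounds alone.

In a functional assay with Cavia porcellus as the target (on this read-out lower numbers stand for an effect already at smaller amounts and higher numbers for an effect only at larger amounts of compound), compound 1 (`COC(=O)c1c(C)[nH]c(C)c1C(=O)c1ccccc1C(F)(F)F`) gives 4840 nM. Compound 2 (`COC(=O)c1c(C)[nH]c(C)c1C(=O)c1ccccc1OC(=O)c1ccccc1O`) gives 3800 nM, and the two values lie within the usual scatter of each other. Compound 3 (`COC(=O)c1c[nH]c(C)c1C(=O)c1ccccc1Cc1ccccc1`) gives 144 nM, a number lower than both and beyond the scatter. Compound 1 therefore sits at the upper end of this small set, level with compound 2 and well above compound 3.

The next compound to be measured is compound 4 (`COC(=O)c1c(C)[nH]c(C)c1C(=O)c1ccccc1Br`). It has bromo in place of trifluoromethyl on an aromatic carbon, and the swap can be counted as bromo in place of trifluoromethyl on an aromatic carbon. Among the measured compounds shown here, no two measured compounds differ in only one place, so the data offer no direct precedent for the size of such a step in this assay. The best guide is compound 2, which carries a quite different group and still gives 3800 nM. Compound 3 shows that much lower numbers are possible, but it differs from compound 1 in more than one place. A small move towards a lower number, within the scatter, is the expectation here. The estimated step of a 1.6-fold lower number from compound 1 to compound 4 (0.21 log units; within the scatter) reflects this. For compound 4 the expected value is 3000 nM, with an estimated range from 800 nM to 11000 nM.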

Compound 4, half-maximal effective concentration: 8950 nM
Estimate against measurement, compound 4: 3.0-fold (0.47 log units) below; the range from low to high includes it.
By their numbers in this assay, from the lowest: compound 3; then compounds 2, 1 and 4 (each within the scatter of the next, the first and the last beyond it).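

In this assay, among the compounds shown here, putting bromo in place of trifluoromethyl on this aromatic carbon, ortho to a large group, gives a 1.8-fold higher number from compound 1 to compound 4 (0.27 log units; within the scatter), and this is the first comparison in the set between compounds that differ in one place only. The two compounds therefore stand level, so for this one pair, going from a group of 4 heavy atoms to a group of 1 heavy atom leaves the read-out inside the normal spread of repeat measurements, and the shared core tolerates either group equally well in this assay. No measured property of these groups is available that could explain this result.

Going by these compounds, it remains open whether any group on this aromatic carbon can move the number beyond the scatter, since a single pair says nothing about a methoxy group, an amine or a carboxylic acid there. On these data alone, it also remains open which structural difference goes with the much lower number of compound 3, at 144 nM, since compound 3 differs from compound 1 in more than one place and no single change can be singled out.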